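This account rests on a few compounds, and the source may have more. Where it says the series, first, only, none or still open, it means among the compounds named here.

Working notes, melanoma growth series. All numbers come from a functional assay on cells (Melanoma cell, Homo sapiens) for inhibition; a lower number here means a stronger inhibitor of growth, a higher number a weaker inhibitor of growth.

Measured:
- compound 1, `Cc1cc(-c2nc3sc(C)cn3c2/C=N/NC(=N)N)c(C)s1`: 7410 nM
- compound 2, `Cc1cn2c(/C=N/NC(=N)N)c(-c3ccsc3)nc2s1`: 8130 nM
- compound 3, `N=C(N)N/N=C/c1c(-c2ccsc2)nc2n1CCS2`: 21900 nM

Compounds 1 and 2 share a core and differ only in one place: 2,5-dimethylthiophen-3-yl in place of thiophen-3-yl on an aromatic carbon. The step is a 1.1-fold lower number from compound 2 to compound 1 (0.04 log units; within the scatter), so the two values cannot be ordered. Compound 3 carries a different core; the difference between the two cores is not broken down here. Compound 3 gives the highest number of the three, and its gap to compound 2 and to compound 1 is beyond the scatter.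

Not yet measured is compound 4, `Cc1cc(-c2nc3n(c2/C=N/NC(=N)N)CCS3)c(C)s1`. Against compound 3 the change is 2,5-dimethylthiophen-3-yl in place of thiophen-3-yl on an aromatic carbon. The place is described in the same words as for the step from compound 2 to compound 1, except that on the core of compound 3 the carbon is also two ring bonds from two ring atoms that each bear a fused ring, so this is the same kind of change, not the same change. Among the compounds with values here, the only precedent, from compound 2 to compound 1, moved the number within the scatter; the step from compound 3 to compound 4 is expected to be of similar size, a 1.1-fold lower number from compound 3 to compound 4 (0.04 log units; within the scatter). Compound 4 is therefore estimated at 20000 nM, with a range from 9000 nM to 45000 nM.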

Compound 4, concentration for 50% growth inhibition: 15500 nM
For compound 4 the middle estimate is 1.3-fold (0.11 log units) above the measured one; low and high end bracket the measured number.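

In this assay, 2,5-dimethylthiophen-3-yl in place of thiophen-3-yl gives a 1.4-fold lower number from compound 3 to compound 4 (0.15 log units; within the scatter), so compound 3 and compound 4 cannot be ordered. Set beside the earlier case, the change carries from one core to the other with no detectable difference in its size: the same change on two cores in this assay, a 1.1-fold lower number (0.04 log units; within the scatter) from compound 2 to compound 1 and a 1.4-fold lower number (0.15 log units; within the scatter) from compound 3 to compound 4, 1.3-fold (0.11 log units) apart, within the scatter of two such steps. Within the data shown here, this shows only that the change leaves the number within the scatter on these two cores in this one read-out; it does not show that the same would hold on any further core, and it gives no reason for the result.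

Open, on these data alone, is whether a different group on the thiophene, such as a chlorine or an amine, or a phenyl in place of the thiophene, would move the number beyond the scatter on either core. Also open, as far as these compounds go, is what a carboxylic acid would do in place of the group of 6 heavy atoms borne on the neighbouring ring atom.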